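A few compounds are considered here, and "the series" means these few. Any claim that something is new, unique, unknown or untested is made for them only; others in the source may bear on it.

In a functional assay on isolated protein for inhibition of Glucose-dependent insulinotropic receptor (Rattus norvegicus), read by HTRF and cAMP accumulation (on this read-out higher numbers stand for larger maximal responses and lower numbers for smaller maximal responses), compound 2 `Cc1nc(S(C)(=O)=O)ccc1Oc1ncnc(OC2CCN(C(=O)OC(C)F)CC2)c1F` gives 68%, the lowest of the three values recorded; compound 3 `Cc1nc(S(C)(=O)=O)ccc1Oc1ncnc(OC2CCN(C(=O)O[C@H](C)CF)CC2)c1F` gives 79% and compound 1 `Cc1nc(S(C)(=O)=O)ccc1Oc1ncnc(OC2CCN(C(=O)OC(C)(C)CF)CC2)c1F` gives 95%. Compound 4 `Cc1nc(S(C)(=O)=O)ccc1Oc1ncnc(OC2CCN(C(=O)SC3CC3)CC2)c1F` differs from compound 2 as follows: a group of 4 heavy atoms (3 carbon, 1 sulfur; one three-membered non-aromatic ring of carbon only) in place of a group of 4 heavy atoms (2 carbon, 1 oxygen, 1 fluorine; no ring), on a carbonyl carbon. Going by the values given here, no measured step replaces the oxygen on the carbonyl carbon or brings in a ring; the steps that bear on this position only reshape the group on that oxygen, giving a number 11 percentage points higher from compound 2 to compound 3 (beyond the scatter) and a number 27 percentage points lower from compound 1 to compound 2 (beyond the scatter). Such changes at the carbonyl group moved this assay modestly, so a modest step from compound 2 is expected, direction uncertain, as a number 12 percentage points higher from compound 2 to compound 4 (beyond the scatter). Compound 4 is therefore expected to show about 80%, within a range of 60% to 100%.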

Compound 4, largest response reached (reported as efficacy), in percent of the reference or control that the assay uses: 80%
For compound 4 middle estimate and measured number coincide at the digits printed; the measured number falls inside the stated range.
By their numbers in this assay, from the lowest: compound 2; then compounds 3 and 4 (each within the scatter of the next); then compound 1.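

In this assay, going by these compounds alone, a group holding sulfur and a three-membered carbon ring is accepted on the carbonyl carbon, a change no earlier step covered: it gives a number 12 percentage points higher from compound 2 to compound 4 (beyond the scatter), a number 1 percentage points higher from compound 3 to compound 4 (within the scatter) and a number 15 percentage points lower from compound 1 to compound 4 (beyond the scatter). The oxygen on this carbonyl carbon and the open fluorinated chains are therefore not needed for a substantial maximal response. No available evidence bears on these steps. Sulfur and the ring enter together, so the compounds shown do not separate their contributions. An open-chain ethyl group on the sulfur would bear on that question.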